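Carbonate to carbamate: a step expected to lengthen half-life

The compounds below may be only part of what the source reports. "The series", "measured", "known", "first", "only" and "open" are said of these compounds alone.

Compound 2 `Cc1cn(C2CC(N=[N+]=[N-])C(COC(=O)OCCO)O2)c(=O)[nH]c1=O` carries 2-hydroxyethoxy on a carbonyl carbon. In an ADME assay on the whole organism (serum) with Homo sapiens as the target (on this read-out higher numbers stand for a longer-lived compound and lower numbers for a shorter-lived compound), compound 2 gives < 0.0167 h, which is a limit of the assay and not a number (the limit of < 0.0167 h in this assay, at which 1 of the 2 values shown sits). Of the two values known, compound 2 therefore sits at the short-lived end. The other measured compound, compound 1 `Cc1cn(C2CC(N=[N+]=[N-])C(COC(=O)NCCCC(=O)O)O2)c(=O)[nH]c1=O`, carries (3-carboxypropyl)amino on the same carbonyl carbon. In this assay compound 1 gives > 48 h, again a limit rather than a number (the limit of > 48 h in this assay, at which 1 of the 2 values shown sits). Within the data shown here, the one measured step, an at least 2800-fold lower number from compound 1 to compound 2 (3.45 log units; beyond the scatter), was large and ran from a carbamate to a carbonate. Compound 3 `Cc1cn(C2CC(N=[N+]=[N-])C(COC(=O)NCCCO)O2)c(=O)[nH]c1=O` differs from compound 2 by (3-hydroxypropyl)amino in place of 2-hydroxyethoxy on a carbonyl carbon, so the ((2-hydroxyethoxy)carbonyl)oxy group becomes ((3-hydroxypropyl)carbamoyl)oxy, the same kind of change as that step but in the opposite direction. Among the measured compounds shown here, that step is the only evidence bearing on this one, and it was well beyond the scatter. A large rise is therefore expected, estimated as an at least 1700-fold higher number from compound 2 to compound 3 (3.25 log units; beyond the scatter). Compound 3 is accordingly expected to give about 30 h in this assay, with the likely range from 5 h to 100 h, and a fair chance that only a limit is reported.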

Compound 3, half-life: > 48 h
Compound 3: a limit, no number; the forecaster's own chance of this, stated with the estimate: 50%; at least 1.6-fold (0.20 log units) between middle value and limit.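

In this assay the change on the carbonyl carbon gives an at least 2800-fold higher number from compound 2 to compound 3 (3.45 log units; beyond the scatter), so the large gap between carbonate and carbamate now appears with a hydroxy-ended chain as well as with the carboxy-ended chain of compound 1. The carboxy group is therefore not required for a carbamate of this series to reach the long-lived end of this read-out. Compound 3 gives > 48 h, a limit of the assay and not a number, and the step that joins it to compound 1 cannot be read: the limit of > 48 h in this assay, at which 2 of the 3 values shown sit.

As far as these compounds go, how far either carbamate lies past that limit stays open, and with it whether hydroxy in place of carboxy on the chain shifts the half-life at all. Also open, from the compounds shown here alone, is whether a carbamate with a chain ending in an amine, or with a longer chain, would stay as long-lived, and whether a carbonate carrying a carboxylic acid would be as short-lived as compound 2.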